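Replacing cyclopentyl with 3-methoxypropyl on an oxygen

The compounds below may be only part of what the source reports. "The series", "measured", "known", "first", "only" and "open" are said of these compounds alone.

For the measured compounds named here, in a physicochemical assay for lipophilicity, using the shake flask method (on this read-out lower numbers stand for lower lipophilicity and higher numbers for higher lipophilicity), compound 3 `Nc1ncnc(Oc2ccc(NC(=O)C3(C(=O)Nc4ccc(F)cc4)CC3)cc2F)c1/C=N/OC1CCCC1` gives 4.27, the highest of the three numbers measured so far. Compound 2 `Nc1ncnc(Oc2ccc(NC(=O)C3(C(=O)Nc4ccc(F)cc4)CC3)cc2F)c1/C=N/OCCCN1CCCC1` gives 3.82 and compound 1 `CC(C)(C)OC(=O)N/N=C/c1c(N)ncnc1Oc1ccc(NC(=O)C2(C(=O)Nc3ccc(F)cc3)CC2)cc1F` gives 3.7. These two do not separate, as the data show a number 0.12 log units higher from compound 1 to compound 2 (within the scatter).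

Compound 4 `COCCCO/N=C/c1c(N)ncnc1Oc1ccc(NC(=O)C2(C(=O)Nc3ccc(F)cc3)CC2)cc1F` keeps the shared core of compound 3 and carries 3-methoxypropyl in place of cyclopentyl on an oxygen.

The closest measured comparison is the exchange of a propyl-based chain for cyclopentyl on that same oxygen, which gave a number 0.45 log units higher from compound 2 to compound 3 (beyond the scatter). A more distant comparison, with a different group leaving, gave a number 0.57 log units higher from compound 1 to compound 3 (beyond the scatter). Read in reverse, the first of these points to a modest fall on leaving cyclopentyl, although no measured compound carries the 3-methoxypropyl chain itself. The expected change is a number 0.47 log units lower from compound 3 to compound 4 (beyond the scatter), a modest step downward. Compound 4 is estimated at 3.8, with an expected range of 3.4 to 4.2.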

Compound 4, partition coefficient: 3.18
The estimate for compound 4 lay 0.62 log units above the measured number; the measured number lies below the stated range.
By their numbers in this assay, from the lowest: compound 4; then compounds 1 and 2 (each within the scatter of the next); then compound 3.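

In this assay, for the compounds shown here, the group on this oxygen moves the number further than the earlier compounds showed (a number 1.09 log units lower from compound 3 to compound 4 (beyond the scatter)), although cyclopentyl and 3-methoxypropyl have the same count of heavy atoms and differ in the ring, which leaves, and the hydrogen-bond acceptor, which enters. Compound 4 also has the lowest number of the four, and on the open chain methoxy in place of pyrrolidin-1-yl gives a clear step (a number 0.64 log units lower from compound 2 to compound 4 (beyond the scatter)), as does the exchange from the (tert-butoxycarbonyl)amino compound (a number 0.52 log units lower from compound 1 to compound 4 (beyond the scatter)). Nothing available explains the size of the fall.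

Going by these compounds, it remains open whether a hydroxyl or morpholin-4-yl group on the same chain would give a number nearer compound 2 or compound 4. The compounds shown also leave open how 2-methoxyethyl or a longer methoxyalkyl chain would compare with 3-methoxypropyl.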